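Replacing the anilino link of compound 2 by an aryl ether

The source may report more compounds than this note shows. Statements on the series, on what has been measured and on what is new or still open speak of the compounds shown alone.

In a functional assay on HEK293 cells for agonist activity at Glucose-dependent insulinotropic receptor (Mus musculus), read by fluorescence and cAMP accumulation, with a stated time of 30 min (a higher number here means a larger maximal response, a lower number a smaller maximal response), compound 2 `Cc1c(Nc2ccc(C#N)cc2Cl)ncnc1OC1C2COCC1CN(C(=O)OC1(C)CC1)C2` gives 102%, the higher of the two numbers recorded, while compound 1 `COc1c(Nc2ccc(C#N)cc2Cl)ncnc1OC1C2COCC1CN(C(=O)OC1(C)CC1)C2` gives 99%; the two lie within the scatter, as the step of a number 3 percentage points higher from compound 1 to compound 2 (within the scatter) shows. Compound 3 `Cc1c(Oc2ccc(C#N)cc2Cl)ncnc1OC1C2COCC1CN(C(=O)OC1(C)CC1)C2` differs from compound 2 as follows: 2-chloro-4-cyanophenoxy in place of (2-chloro-4-cyanophenyl)amino on an aromatic carbon. Among the compounds with values here, no measured step touches this change, since a number 3 percentage points higher from compound 1 to compound 2 (within the scatter) concerns only methyl in place of methoxy. For compound 3 a maximal response near that of compound 2 is therefore expected, with no step beyond the scatter, namely a number 7 percentage points lower from compound 2 to compound 3 (within the scatter), and the estimate is 95% within 55% to 115%.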

Compound 3, largest response reached (reported as percent of maximum), in percent of the reference or control that the assay uses: 143%
For compound 3 the middle estimate is 48 percentage points below the measured one; the measured number lies above the stated range.
By their numbers in this assay, from the lowest: compounds 1 and 2 (each within the scatter of the next); then compound 3.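

On this aromatic carbon, next to the ring nitrogen and ortho to a methyl group, 2-chloro-4-cyanophenoxy in place of (2-chloro-4-cyanophenyl)amino gives a number 41 percentage points higher from compound 2 to compound 3 (beyond the scatter) in this assay. The maximal response therefore depends strongly on the link at this position, a sensitivity that a number 3 percentage points higher from compound 1 to compound 2 (within the scatter), at a different position, did not reveal. No measurement given here bears on why the response rises.

On these data alone, it remains open whether a thioether or methylene link would give a similar response. As far as these compounds go, it is also open whether the aryl ether would raise the response with methoxy in place of the methyl group.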